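This account rests on a few compounds, and the source may have more. Where it says the series, first, only, none or still open, it means among the compounds named here.

In a functional assay on A549 cells (Homo sapiens) for cytotoxicity, read by MTT assay, with a stated time of 72 h (on this read-out lower numbers stand for stronger inhibition and higher numbers for weaker inhibition), compound 3 `O=C(CN1CCN(c2nnc(Cc3ccccc3)c3ccccc23)CC1)Nc1ccc(Br)cc1` gives 2000 nM. This lies within the usual scatter of compound 2 `O=C(CN1CCN(c2nnc(Cc3ccncc3)c3ccccc23)CC1)Nc1cccc(Br)c1` at 1530 nM, while compound 1 `O=C(CN1CCN(c2nnc(Cc3ccccc3)c3ccccc23)CC1)Nc1c(F)cccc1F` at 84500 nM stands far higher. Compound 4 `O=C(CN1CCN(c2nnc(Cc3ccccc3)c3ccccc23)CC1)Nc1cccc(Br)c1` has 3-bromophenyl in place of 4-bromophenyl on an amide-type nitrogen. Among the measured compounds shown here, the one measured step of this kind, a 42-fold lower number from compound 1 to compound 3 (1.63 log units; beyond the scatter), is large, but it replaces 2,6-difluorophenyl, a different group, so it offers only a loose guide. Compound 2 also carries 3-bromophenyl, though it differs elsewhere, and its 1530 nM gives no sign of a large shift. In this assay, no step beyond the scatter is therefore expected, and the estimated change is a 1.1-fold lower number from compound 3 to compound 4 (0.05 log units; within the scatter). Compound 4 is expected at 1800 nM, with an estimated range of 750 nM to 4500 nM.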

Compound 4, half-maximal inhibitory concentration: "not active" (no number reported)
Compound 4 has no reported number here; no gap can be computed for the estimate.
By their numbers in this assay, from the lowest: compounds 2 and 3 (each within the scatter of the next); then compound 1.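

Among the compounds shown here, compound 4 is reported only as "not active", with no number, so no step from compound 3 to compound 4 can be read. As far as these compounds go, how far 3-bromophenyl in place of 4-bromophenyl shifts the number stays open, and no available evidence bears on this result.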